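Swapping the Amide Substituent in a Cytotoxicity Series

The source may report more compounds than this note shows. Statements on the series, on what has been measured and on what is new or still open speak of the compounds shown alone.

Compound 1 `C=CC1=C(C(=O)NCc2ccc(Cl)cc2)C(c2ccc(F)cc2)OC1` was tested in a functional assay on HeLa cells (Homo sapiens) for cytotoxicity, read by MTT assay, with a stated time of 24 h; on this read-out lower numbers stand for stronger inhibition and higher numbers for weaker inhibition. In this assay compound 1 gives only a limit, > 100000 nM. Compound 2 `C=CC1=C(C(=O)NCc2ccc(Cl)cc2)C(c2ccc(OC)cc2)OC1` also gives only a limit in this assay, > 100000 nM. The step that the two limits leave unreadable from compound 1 to compound 2 is therefore not readable, since both values sit at the limit of > 100000 nM in this assay, at which 2 of the 2 values shown sit. Compound 3 `C=CC1=C(C(=O)NC2CCCCC2)C(c2ccc(F)cc2)OC1` carries cyclohexyl in place of 4-chlorobenzyl on an amide-type nitrogen. Going by the values given here, no measured step touches this change, and the two known values are limits, so no direction or size can be expected beyond the scatter. Compound 3 is expected to give 150000 nM, in a range from 50000 nM to 500000 nM. The expected step is a step that the limit leaves unreadable from compound 1 to compound 3.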

Compound 3, half-maximal inhibitory concentration: > 100000 nM
Compound 3 gave a limit, no number (the forecaster's own chance of this, stated with the estimate: 80%); the middle value lies beyond the limit too.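

Compound 1 and compound 3 each give only a limit in this assay, so no step can be read between them: the limit of > 100000 nM in this assay, at which 3 of the 3 values shown sit.

The compounds shown leave open how either amide substituent affects potency, since none of them gives a number in this assay.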